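The compounds below may be only part of what the source reports. "The series", "measured", "known", "first", "only" and "open" are said of these compounds alone.

In an assay on CHO-K1 cells for displacement of a labelled ligand from prostaglandin E2 receptor EP1 subtype (Homo sapiens) (on this read-out higher numbers stand for weaker inhibition and lower numbers for stronger inhibition), compound 1 `Cc1cc(C(=O)O)nn1Cc1cc(Br)ccc1OCc1ccc(Cl)cc1Cl` gives 0.132 nM. Compound 2 `Cc1cc(C(=O)O)nn1Cc1cc(Br)ccc1OCc1ccccc1Cl` gives 3.16 nM in this assay, and compound 3 `Cc1cc(C(=O)O)nn1Cc1cc(Br)ccc1OCc1cccc(C(F)(F)F)c1` gives 309 nM, the highest of the three numbers. The change from compound 2 to compound 1 is chloro in place of hydrogen on an aromatic carbon, and it made a step of a 24-fold lower number from compound 2 to compound 1 (1.38 log units; beyond the scatter). The same kind of change separates compound 3 from compound 4 `Cc1cc(C(=O)O)nn1Cc1cc(Br)ccc1OCc1ccc(Cl)c(C(F)(F)F)c1`: chloro in place of hydrogen on an aromatic carbon. The place is not identical, since in compound 4 the entering chloro is ortho to a trifluoromethyl group, whereas in compound 1 it is meta to a chloro group. The difference between the cores of compound 2 and compound 3 is not broken down here. Because the step of a 24-fold lower number from compound 2 to compound 1 (1.38 log units; beyond the scatter) was large, a clear but somewhat smaller step is expected for compound 4, a 10-fold lower number from compound 3 to compound 4 (1.01 log units; beyond the scatter). Compound 4 is thus estimated at 30 nM, within 6 nM to 150 nM.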

Compound 4, half-maximal inhibitory concentration: 575 nM
Compound 4: the middle estimate sits 19-fold (1.28 log units) below what was measured; the whole stated range lies below it.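

The change of chloro in place of hydrogen on an aromatic carbon did not carry over from one core to the other: the same change on two cores in this assay, a 24-fold lower number (1.38 log units; beyond the scatter) from compound 2 to compound 1 and a 1.9-fold higher number (0.27 log units; within the scatter) from compound 3 to compound 4, 45-fold (1.65 log units) apart, beyond the scatter of two such steps. With the entering chloro ortho to a trifluoromethyl group, the step is a 1.9-fold higher number from compound 3 to compound 4 (0.27 log units; within the scatter) and shows none of the drop seen on the core of compound 2. The two pairs do not show what separates them, since the cores and the surroundings of the chloro both differ, and two pairs set no rule for the series.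

The compounds shown leave open whether the trifluoromethyl group itself decides the outcome. They also leave open how a fluoro or methoxy group would behave in place of the entering chloro.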